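The compounds below may be only part of what the source reports. "The series", "measured", "known", "first", "only" and "open" are said of these compounds alone.

Compound 1, `Cc1nc(N2CCN(C)CC2)cc(-c2ccccc2)c1C(=O)NCc1cc(C(F)(F)F)cc(C(F)(F)F)c1`, carries a 4-methylpiperazin-1-yl group on its core and an amide bearing a hydrogen. In an assay on CHO cells for displacement of a labelled ligand from Substance-P receptor (Homo sapiens), with a stated time of 90 min (on this read-out lower numbers stand for stronger inhibition and higher numbers for weaker inhibition), compound 1 gives 53 nM. Compound 2, `Cc1nc(N2CCN(C)CC2)cc(-c2ccccc2)c1C(=O)N(C)Cc1cc(C(F)(F)F)cc(C(F)(F)F)c1`, differs from compound 1 only at the amide nitrogen, (methyl in place of hydrogen on an amide-type nitrogen), and in this assay compound 2 gives 4.8 nM, so that the change produced an 11-fold lower number from compound 1 to compound 2 (1.04 log units; beyond the scatter).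

Compound 3, `Cc1cc(-c2ccccc2)c(C(=O)NCc2cc(C(F)(F)F)cc(C(F)(F)F)c2)c(C)n1`, is built on a different core: relative to compound 1 the difference is methyl in place of 4-methylpiperazin-1-yl on an aromatic carbon. In this assay compound 3 gives 434 nM, the highest of the three numbers, and the step from the core of compound 1 to that of compound 3 is an 8.2-fold higher number from compound 1 to compound 3 (0.91 log units; beyond the scatter).

Compound 4, `Cc1cc(-c2ccccc2)c(C(=O)N(C)Cc2cc(C(F)(F)F)cc(C(F)(F)F)c2)c(C)n1`, is not yet measured in this assay. It stands to compound 3 as compound 2 stands to compound 1: the difference is methyl in place of hydrogen on an amide-type nitrogen, and the place is described in the same terms for both pairs, so this is the same change, now carried out on the core of compound 3. Going by the values given here, the only guide to its likely effect is the one earlier instance, on the core of compound 1, which gave an 11-fold lower number from compound 1 to compound 2 (1.04 log units; beyond the scatter). Whether that effect carries over to a core lacking the 4-methylpiperazin-1-yl group is unknown; no second example exists among these compounds.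

Because compound 1 to compound 2 gave an 11-fold lower number from compound 1 to compound 2 (1.04 log units; beyond the scatter), a similar step, a 9.6-fold lower number from compound 3 to compound 4 (0.98 log units; beyond the scatter), is expected for compound 4. Compound 4 is therefore estimated to give 45 nM in this assay, with a plausible range from 15 nM to 130 nM.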

Compound 4, half-maximal inhibitory concentration: 41 nM
The estimate for compound 4 lay 1.1-fold (0.04 log units) above the measured number, within the range that was stated.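

In this assay, methyl in place of the amide hydrogen on the core of compound 3 gave an 11-fold lower number from compound 3 to compound 4 (1.02 log units; beyond the scatter), and this step matches the one seen on the core of compound 1: the same change on two cores in this assay, an 11-fold lower number (1.04 log units; beyond the scatter) from compound 1 to compound 2 and an 11-fold lower number (1.02 log units; beyond the scatter) from compound 3 to compound 4, 1.0-fold (0.02 log units) apart, within the scatter of two such steps. With methyl already on the amide nitrogen, methyl in place of 4-methylpiperazin-1-yl on an aromatic carbon gave an 8.5-fold higher number from compound 2 to compound 4 (0.93 log units; beyond the scatter), and this step likewise matches its earlier counterpart: the same change on two cores in this assay, an 8.2-fold higher number (0.91 log units; beyond the scatter) from compound 1 to compound 3 and an 8.5-fold higher number (0.93 log units; beyond the scatter) from compound 2 to compound 4, 1.0-fold (0.02 log units) apart, within the scatter of two such steps. The four compounds therefore show each change carrying over between these two cores with its size intact, but each comparison rests on a single pair in one assay, so this does not show that the same would hold on any other core, and it does not explain why the steps agree.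

The compounds shown leave open whether a longer chain on the amide nitrogen, such as ethyl, would give a step of similar size on both cores. They also leave open whether another amine in place of the 4-methylpiperazin-1-yl group, such as morpholine or an open-chain dimethylamine, would combine with the amide methyl in the same way.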